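The source may hold more compounds than are shown below. What is called first, only, known or untested is meant among the compounds shown, and "the series" means these compounds.

Going by the values given here, compound 3 `ClCc1ccccc1Cn1cnc2c(Cl)ncnc21` gives 3020 nM in a functional assay on MDA-MB-435 cells (Homo sapiens) for cytotoxicity, read by sulforhodamine B assay, with a stated time of 48 h (a higher number here means a weaker inhibitor of growth, a lower number a stronger inhibitor of growth), the second highest of the three numbers measured so far. Its nearest neighbour is compound 1 `ClCc1ccccc1Cn1cnc2c(Cl)nc(Cl)nc21`, which gives 1620 nM in this assay. Among the compounds with values here, the only step on record, a 1.9-fold higher number from compound 1 to compound 3 (0.27 log units; within the scatter), stays within the scatter. Furthest from it stands compound 2 `Nc1nc(Cl)c2ncn(Cc3ccc(CCl)cc3)c2n1`, which gives 16600 nM in this assay; that gap lies beyond the scatter, but compound 2 differs from compound 3 in two places, so its value shows only where one amino-bearing compound came out.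

Compound 4 `Nc1nc(Cl)c2ncn(Cc3ccccc3CCl)c2n1` differs from compound 3 by amino in place of hydrogen on an aromatic carbon. Within the data shown here, no measured step isolates this change, and the single step on record concerns a different group. The amino-bearing compound 2, with 16600 nM in this assay, is the only hint, and it points towards a higher number. Compound 4 is therefore expected to give 6000 nM in this assay, within 2000 nM to 18000 nM. This corresponds to an expected step of a 2.0-fold higher number from compound 3 to compound 4 (0.30 log units; within the scatter).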

Compound 4, concentration for 50% growth inhibition: 6030 nM
Compound 4: the middle estimate sits 1.0-fold (0.00 log units) below what was measured, within the range that was stated.
By their numbers in this assay, from the lowest: compounds 1, 3 and 4 (each within the scatter of the next, the first and the last beyond it); then compound 2.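

At this carbon between two ring nitrogen atoms, amino in place of hydrogen gives a 2.0-fold higher number from compound 3 to compound 4 (0.30 log units; within the scatter) in this assay, so this change cannot be told apart from the scatter. Amino in place of chloro on the same carbon gives a 3.7-fold higher number from compound 1 to compound 4 (0.57 log units; beyond the scatter), the first step at this position to pass beyond the scatter, though only modestly. Taken together, the three compounds separate amino from chloro at this carbon but not amino from hydrogen or hydrogen from chloro, so the one clear difference rests on a single pair.

On these data alone, whether a methoxy group, a hydroxyl group or a dimethylamino group on this carbon would give a step beyond the scatter from hydrogen remains open. No measurement shown here explains why amino and chloro differ at this position.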